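Aryl Swap on a Sulfonamide-Amine Chain: Compound 4

The source may hold more compounds than are shown below. What is called first, only, known or untested is meant among the compounds shown, and "the series" means these compounds.

Measured compounds:
compound 1, `O=S(=O)(NCCCCNCc1ccc(Br)cc1)c1cc(C(F)(F)F)cc(C(F)(F)F)c1`, 2100 nM
compound 2, `COc1cccc(CNCCCNS(=O)(=O)c2cc(C(F)(F)F)cc(C(F)(F)F)c2)c1`, 3400 nM
compound 3, `O=S(=O)(NCCCCCCNCc1ccc(Br)cc1)c1cc(C(F)(F)F)cc(C(F)(F)F)c1`, 2970 nM

All three values were obtained in a functional assay on MIA PaCa-2 cells (Homo sapiens) for inhibition, read by MTT assay, with a stated time of 72 h; a lower number here means a stronger inhibitor of growth, a higher number a weaker inhibitor of growth. Compound 2 gives the highest of the three numbers, yet its gap to compound 3, the nearest, and to compound 1, the furthest, both lie within the scatter, so no order can be read among them. Compound 4, `O=S(=O)(NCCCNCc1ccc(Cl)c(C(F)(F)F)c1)c1cc(C(F)(F)F)cc(C(F)(F)F)c1`, is the unmeasured analogue. It differs from compound 2 by 4-chloro-3-(trifluoromethyl)phenyl in place of 3-methoxyphenyl on a saturated chain carbon bound to an amine nitrogen.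

Going by the values given here, two measured steps touch this series. The step of a 1.6-fold higher number from compound 1 to compound 2 (0.21 log units; within the scatter) combines a change of the aryl group with a change of the chain and stays within the scatter; the step of a 1.4-fold higher number from compound 1 to compound 3 (0.15 log units; within the scatter) alters only the chain and also stays within the scatter. Among the compounds with values here, neither step isolates the aryl swap that leads to compound 4, so there is no direct precedent for it. What the data show is a series in which every change so far has left this assay essentially flat.

Compound 4 is therefore expected to sit close to its parent, with an estimated step of a 1.4-fold lower number from compound 2 to compound 4 (0.13 log units; within the scatter) that need not exceed the scatter. For compound 4 the estimate in this assay is 2500 nM, ranging from 1100 nM to 5500 nM.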

Compound 4, concentration for 50% growth inhibition: 7400 nM
Compound 4: the middle estimate sits 3.0-fold (0.47 log units) below what was measured; measured number outside the range, above it.
By their numbers in this assay, from the lowest: compounds 1, 3 and 2 (each within the scatter of the next); then compound 4.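

In this assay, going by these compounds alone, putting 4-chloro-3-(trifluoromethyl)phenyl in place of 3-methoxyphenyl on a saturated chain carbon bound to an amine nitrogen gives a 2.2-fold higher number from compound 2 to compound 4 (0.34 log units; beyond the scatter) and so yields the first step to pass beyond the scatter, though only modestly. The earlier steps shown here had left this assay flat, and the one that touched the aryl group also changed the chain, whereas here the chain stays the same and the aryl group alone moves the number toward weaker inhibition of growth. The swap brings in chlorine and fluorine and removes the oxygen of the methoxy group, and nothing given here bears on why the number rises.

Within the data shown here, a single swap cannot show whether the chloro group, the trifluoromethyl group or the loss of the methoxy group carries the step, and compounds with only one of these changes would be needed to separate them. As far as these compounds go, it also remains open how a nitrile or a carboxylic acid would behave on the aryl ring, and whether 4-chloro-3-(trifluoromethyl)phenyl would give a similar step on the longer chains of compound 1 and compound 3.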